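Isobutyl in Place of Cyclopropyl on the Carbonyl Carbon

The compounds below may be only part of what the source reports. "The series", "measured", "known", "first", "only" and "open" are said of these compounds alone.

Compound 1 `CC1=C(C(=O)CC(C)C)C(c2ccco2)NC(=O)N1`: 31%
Compound 2 `CC1=C(C(=O)C2CC2)C(c2cccs2)NC(=O)N1`: 15%

Of the compounds shown here, two have been measured in an assay on membranes from HeLa cells for displacement of a labelled ligand from adenosine receptor A3 (Homo sapiens), read by scintillation counting, with a stated time of 180 min, tested at 1 uM; on this read-out higher numbers stand for more inhibition at the one concentration tested (going by the name of the read-out) and lower numbers for less inhibition. Compound 1 gives 31%. Compound 2 gives 15%, the lowest of the two numbers, and its gap to compound 1 lies beyond the usual scatter. Compound 3 `CC1=C(C(=O)CC(C)C)C(c2cccs2)NC(=O)N1` has not been measured; it differs from compound 2 in one place: isobutyl in place of cyclopropyl on a carbonyl carbon. Going by the values given here, compound 1 also carries isobutyl on its carbonyl carbon, but it differs from compound 2 in a second place as well, so the two measured values show only what that pair shows and give no step for this change on its own. Because compound 1 gives 31% with isobutyl present, compound 3 is expected to rise from compound 2 by a step of a number 10 percentage points higher from compound 2 to compound 3 (within the scatter), modest and uncertain in size. Compound 3 is estimated at 25%, within a range from 8% to 45%.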

Compound 3, a percentage reported as inhibition, at one concentration (the size of the read-out at that concentration, not a potency): 18%
Compound 3: middle estimate off by 7 percentage points, on the high side, within the range that was stated.
By their numbers in this assay, from the lowest: compounds 2 and 3 (each within the scatter of the next); then compound 1.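

In this assay, isobutyl in place of cyclopropyl on the carbonyl carbon gives a number 3 percentage points higher from compound 2 to compound 3 (within the scatter), so with thiophen-2-yl on the saturated ring carbon, this exchange of a ring for an open chain on the carbonyl carbon leaves the number within the usual scatter. With isobutyl held in place, thiophen-2-yl in place of furan-2-yl on a saturated ring carbon gives a number 13 percentage points lower from compound 1 to compound 3 (beyond the scatter), and this is the only one of the two single changes whose step lies beyond the scatter. Nothing available accounts for either step.

Going by these compounds, whether the cyclopropyl to isobutyl exchange stays this small with furan-2-yl on the saturated ring carbon remains open. On these data alone, it is also open how a longer chain, an amine or a carboxylic acid on the carbonyl carbon would read.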